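The compounds below may be only part of what the source reports. "The series", "measured", "known", "first", "only" and "open" are said of these compounds alone.

Of the compounds shown here, three have been measured so far.

Compound 1, `CC(C)CCc1c(OCCCCCC(=O)NO)ccc2ccc(=O)oc12`: in a functional assay on PC-3 cells (Homo sapiens) for antiproliferative activity, read by sulforhodamine B assay, with a stated time of 48 h (a lower number here means a stronger inhibitor of growth, a higher number a weaker inhibitor of growth), compound 1 gives 740 nM.
Compound 2, `CC(C)CCc1c(OCCCCCCC(=O)NO)ccc2ccc(=O)oc12`: in this assay compound 2 gives 520 nM.
Compound 3, `CC(C)CCc1c(OCCCCC(=O)NO)ccc(CCC(=O)NO)c1O`: in this assay compound 3 gives 14400 nM.

Compound 1 and compound 2 share one core and differ in a single place: (hydroxycarbamoyl)methyl in place of hydroxycarbamoyl on a saturated chain carbon, five bonds along the chain from an oxygen on an aromatic ring. That change gave a 1.4-fold lower number from compound 1 to compound 2 (0.15 log units; within the scatter). Compound 3 rests on a different core; how the two cores differ is not broken down here, and its value stands far apart from those of compound 1 and compound 2.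

Compound 4, `CC(C)CCc1c(OCCCCCC(=O)NO)ccc(CCC(=O)NO)c1O`, has not yet been measured. It differs from compound 3 by (hydroxycarbamoyl)methyl in place of hydroxycarbamoyl on a saturated chain carbon, four bonds along the chain from an oxygen on an aromatic ring. Going by the values given here, this is the same kind of change as the one from compound 1 to compound 2, though the place is four bonds along the chain from an oxygen on an aromatic ring rather than five. Because the earlier change gave a 1.4-fold lower number from compound 1 to compound 2 (0.15 log units; within the scatter), the step from compound 3 to compound 4 is expected to be about as small, a 1.4-fold lower number from compound 3 to compound 4 (0.16 log units; within the scatter). Compound 4 is therefore estimated at 10000 nM in this assay, with the likely range between 5000 nM and 20000 nM.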

Compound 4, concentration for 50% growth inhibition: 2520 nM
The estimate for compound 4 lay 4.0-fold (0.60 log units) above the measured number; measured number outside the range, below it.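

In this assay putting (hydroxycarbamoyl)methyl in place of hydroxycarbamoyl gave a 5.7-fold lower number from compound 3 to compound 4 (0.76 log units; beyond the scatter) on the core of compound 3. The same change did not give a step of the same size on the two cores: the same change on two cores in this assay, a 1.4-fold lower number (0.15 log units; within the scatter) from compound 1 to compound 2 and a 5.7-fold lower number (0.76 log units; beyond the scatter) from compound 3 to compound 4, 4.0-fold (0.60 log units) apart, beyond the scatter of two such steps. The size of this step therefore did not carry over between these two cores, but two pairs give no rule for other cores, the place also differs (four bonds along the chain rather than five), and these numbers do not show why the steps differ.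

The compounds shown leave open whether a still longer chain would lower the number further on the core of compound 4. They also leave open how a carboxylic acid in place of the hydroxycarbamoyl end would behave.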